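Walking the fluorine around the aryl ring of a shared core

The compounds below may be only part of what the source reports. "The series", "measured", "known", "first", "only" and "open" are said of these compounds alone.

Compound 2 `Fc1ccc(-c2cc(-c3cnn(C4CCNCC4)c3)on2)c(Cl)c1` is the higher of the two measured compounds in an assay on a protein complex for positive allosteric modulation of Neuronal acetylcholine receptor; alpha4/beta2 (Homo sapiens); a lower number here means a smaller maximal response, a higher number a larger maximal response: there compound 2 gives 56%, while compound 1 `Fc1ccc(Cl)c(-c2cc(-c3cnn(C4CCNCC4)c3)on2)c1` gives 29%. For the measured compounds named here, the only measured step, a number 27 percentage points higher from compound 1 to compound 2 (beyond the scatter), moved the fluorine of the aryl group one position and changed the maximal response by a modest amount, beyond the scatter. Compound 3 `Fc1cccc(-c2cc(-c3cnn(C4CCNCC4)c3)on2)c1Cl` differs from compound 2 by 2-chloro-3-fluorophenyl in place of 2-chloro-4-fluorophenyl on an aromatic carbon. This is again a move of the fluorine alone, so the step from compound 1 to compound 2 is the only one that bears on it; it shows that such a move can shift the response by about that much, but gives no guide to the direction for the new position. A step of similar size in either direction is therefore plausible, and compound 3 is expected to give 45% in this assay, within 20% to 75%, meaning an expected step of a number 11 percentage points lower from compound 2 to compound 3 (beyond the scatter).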

Compound 3, largest response reached (reported as efficacy), in percent of the reference or control that the assay uses: 47%
Compound 3: middle estimate off by 2 percentage points, on the low side, and the stated range covers the measured number.
By their numbers in this assay, from the lowest: compound 1; then compounds 3 and 2 (each within the scatter of the next).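

In this assay, the 2-chloro-3-fluorophenyl group of compound 3 cannot be told apart from the 2-chloro-4-fluorophenyl group of compound 2, with a number 9 percentage points lower from compound 2 to compound 3 (within the scatter). Against the 2-chloro-5-fluorophenyl group of compound 1 it does stand apart, with a number 18 percentage points higher from compound 1 to compound 3 (beyond the scatter), so among these three compounds the step from compound 1 is the one that holds for both other fluorine placements. Nothing measured here says why the placement of the fluorine matters.

Going by these compounds, all three compounds carry the same chlorine and fluorine on the aryl ring, so the effect of a methoxy group or a nitrile in place of the fluorine in this assay remains open. Also open, on these data alone, is whether the pattern would hold with a carboxylic acid on the shared core.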